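Amide aryl variation on the shared core: methoxy to fluoro

This account rests on a few compounds, and the source may have more. Where it says the series, first, only, none or still open, it means among the compounds named here.

Measured so far in a functional assay on GTL 16 cells for antiproliferative activity against GTL 16 cell line (Homo sapiens), read by CCK-8 assay, with a stated time of 72 h; a higher number here means a weaker inhibitor, a lower number a stronger inhibitor:
compound 1 `O=C(Nc1cccc(-c2oc3cc(-c4ccc(F)cc4)ccc3c(=O)c2O)c1)c1ccc(Cl)cc1`: 9140 nM
compound 2 `Cc1ccccc1C(=O)Nc1cccc(-c2oc3cc(-c4ccc(F)cc4)ccc3c(=O)c2O)c1`: 24800 nM
compound 3 `COc1cccc(C(=O)Nc2cccc(-c3oc4cc(-c5ccc(F)cc5)ccc4c(=O)c3O)c2)c1`: 12500 nM

All three share the same core and differ only in the aryl group on the amide carbonyl carbon. Compound 3 stands second highest of the three numbers; its nearest neighbour is compound 1, within the scatter, and its furthest is compound 2, also within the scatter. Among the compounds with values here, the only step beyond the scatter is a 2.7-fold higher number from compound 1 to compound 2 (0.43 log units; beyond the scatter). The steps of a 1.4-fold higher number from compound 1 to compound 3 (0.14 log units; within the scatter) and a 2.0-fold lower number from compound 2 to compound 3 (0.30 log units; within the scatter) are within the scatter.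

Compound 4 `O=C(Nc1cccc(-c2oc3cc(-c4ccc(F)cc4)ccc3c(=O)c2O)c1)c1cccc(F)c1` is not yet measured. The change from compound 3 is fluoro in place of methoxy on an aromatic carbon. Within the data shown here, no measured step exchanges methoxy for fluoro, so the bearing steps are only the aryl swaps above, which span a modest range with compound 3 in the middle of it. A fluoro group in place of methoxy on the same aromatic carbon is therefore expected to give a step of about a 1.1-fold lower number from compound 3 to compound 4 (0.06 log units; within the scatter) in this assay, with no direction preferred beyond the scatter.

Compound 4 is estimated at 11000 nM in this assay, with a range of 5000 nM to 25000 nM.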

Compound 4, half-maximal inhibitory concentration: 15800 nM
Estimate against measurement, compound 4: 1.4-fold (0.16 log units) below; low and high end bracket the measured number.
By their numbers in this assay, from the lowest: compounds 1, 3, 4 and 2 (each within the scatter of the next, the first and the last beyond it).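

Working notes: in this assay, the first direct exchange at this aromatic carbon, meta to a large group, is fluoro in place of methoxy, and it gives a 1.3-fold higher number from compound 3 to compound 4 (0.10 log units; within the scatter). With one heavy atom entering for two and the hydrogen-bond acceptor count of the group going from one to none, this exchange produces no step that can be told from the scatter, so the methoxy group is not shown to be needed on this carbon for the number seen with compound 3. The other two new steps, a 1.6-fold lower number from compound 2 to compound 4 (0.20 log units; within the scatter) and a 1.7-fold higher number from compound 1 to compound 4 (0.24 log units; within the scatter), are also within the scatter, so compound 4 does not separate from any of the other amides, and nothing measured here gives a reason for any of these numbers.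

These four aryl amides leave open whether any group on this carbon can move the number beyond the scatter from compound 3, for example an amine, a carboxylic acid or a longer alkoxy chain. Within the data shown here, they also leave open whether the single step beyond the scatter, a 2.7-fold higher number from compound 1 to compound 2 (0.43 log units; beyond the scatter), would hold up with further aryl groups on the carbonyl carbon.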